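Butyl for Isopropyl on the Amide Nitrogen

A few compounds are considered here, and "the series" means these few. Any claim that something is new, unique, unknown or untested is made for them only; others in the source may bear on it.

Compound 1 `COc1cc2c(cc1OC)C(CC(N)=O)CC2` gives 24.6% in a functional assay on the whole organism (strain Swiss albino) for inhibition, with Mus musculus as the target, in the writhing test, with stated times of 60 min and 15 min, at a dose of 100 mg/kg by the oral route; a lower number here means less inhibition, a higher number more inhibition at the dose given (going by the name of the read-out).
Compound 2 `COc1cc2c(cc1OC)C(CC(=O)NC(C)C)CC2` gives 29.3% in this assay.

For the measured compounds named here, only two compounds have been measured. Compound 2 holds the larger of the two numbers, but a number 4.7 percentage points higher from compound 1 to compound 2 (within the scatter) is within the scatter, so compound 2 stands together with compound 1 rather than apart from it.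

Compound 3 `CCCCNC(=O)CC1CCc2cc(OC)c(OC)cc21` is still to be measured. Its change from compound 2 is butyl in place of isopropyl on an amide-type nitrogen. Going by the values given here, the one measured step that bears on this place, a number 4.7 percentage points higher from compound 1 to compound 2 (within the scatter), put isopropyl where hydrogen had been and did not move the number beyond the scatter. A change from one small alkyl to another at the same nitrogen is therefore expected to do no more, and the account expects a number 0.7 percentage points higher from compound 2 to compound 3 (within the scatter), a step that stays within the scatter. Compound 3 is estimated at 30%, with a range from 15% to 45%.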

Compound 3, a percentage reported as inhibition, in the whole organism at one dose (the size of the read-out at that dose, not a potency): 39.4%
Estimate against measurement, compound 3: 9.4 percentage points below; the range from low to high includes it.
By their numbers in this assay, from the lowest: compounds 1 and 2 (each within the scatter of the next); then compound 3.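

At the amide-type nitrogen, isopropyl in place of hydrogen had stayed within the scatter, but in this assay butyl in place of isopropyl gives a number 10.1 percentage points higher from compound 2 to compound 3 (beyond the scatter), and butyl in place of hydrogen gives a number 14.8 percentage points higher from compound 1 to compound 3 (beyond the scatter). The read-out at this dose therefore does depend on which alkyl group the nitrogen carries: butyl is set apart from both hydrogen and isopropyl, though both steps are modest. No separate data bear on what lies behind this difference.

From the compounds shown here alone, whether a longer chain such as pentyl or hexyl on this nitrogen would raise the number further, or lower it, remains open. Also open, going by these compounds, is how a cyclohexyl or benzyl group, or a second butyl on the same nitrogen, would compare with butyl.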